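This account rests on a few compounds, and the source may have more. Where it says the series, first, only, none or still open, it means among the compounds named here.

Measured in a functional assay on SGC-7901 cells (Homo sapiens) for inhibition, read by MTT assay, with a stated time of 48 h; a lower number here means a stronger inhibitor, a higher number a weaker inhibitor:
- Compound 1 `Cc1nnsc1CO/N=C/c1c(C)nn(C)c1Oc1ccc(Br)cc1`: 15200 nM
- Compound 2 `Cc1nnsc1CO/N=C/c1c(C)nn(C)c1Oc1ccccc1OC(F)(F)F`: > 50000 nM

The entry for compound 2 is a limit of the assay and not a number. For the measured compounds named here, compound 1 therefore holds the only numerical value in this assay, so its rank cannot be placed on a numerical scale.

Compound 3 `Cc1nnsc1CO/N=C/c1c(C)nn(C)c1Oc1cc(F)cc(F)c1` carries 3,5-difluorophenyl in place of 4-bromophenyl on an oxygen on an aromatic ring. Going by the values given here, no measured pair differs in one place only, so no direct precedent sizes this change. The anchor is compound 1 at 15200 nM, and a modest loss of inhibition is expected, possibly no larger than the usual scatter. The expected change is a 1.4-fold higher number from compound 1 to compound 3 (0.16 log units; within the scatter). For compound 3, the estimated value is 22000 nM, with an expected range of 8000 nM to 50000 nM.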

Compound 3, half-maximal inhibitory concentration: 9410 nM
For compound 3 the middle estimate is 2.3-fold (0.37 log units) above the measured one, and the stated range covers the measured number.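

In this assay, 3,5-difluorophenyl in place of 4-bromophenyl on an oxygen on an aromatic ring gives a 1.6-fold lower number from compound 1 to compound 3 (0.21 log units; within the scatter). For the compounds shown here, this is the only step that can be read at this place, and it shows that these two halogen-bearing phenyl groups are not separated in this read-out, so compound 1 and compound 3 count as equivalent here. Compound 2 remains a limit of the assay and not a number: the limit of > 50000 nM in this assay, at which 1 of the 3 values shown sits.

Going by these compounds alone, whether any group at this place can move the number beyond the scatter stays open, since the single readable step lies within it. A phenyl ring carrying an amine or a carboxylic acid, or a pyridine ring on the same oxygen, would test this, and the role of the rest of the shared core is also undefined.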